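A few compounds are considered here, and "the series" means these few. Any claim that something is new, unique, unknown or untested is made for them only; others in the source may bear on it.

The series rests on one shared core; compound 1 `CCC[C@@H]1O[C@H](COCc2ccccc2)[C@@H](OCc2ccccc2)[C@H](OCc2ccccc2)[C@@H]1O`, compound 2 `CCC[C@H]1O[C@H](COCc2ccccc2)[C@@H](OCc2ccccc2)[C@H](OCc2ccccc2)[C@H]1O` and compound 3 `CCC[C@H]1O[C@H](COCc2ccccc2)[C@@H](OCc2ccccc2)[C@H](OCc2ccccc2)[C@@H]1O` carry it and differ only in configuration, as the fact that compounds 1 and 2 differ only in the configuration as drawn, the fact that compounds 1 and 3 differ only in the configuration as drawn and the fact that compounds 2 and 3 differ only in the configuration as drawn record. In a functional assay on HL-60 cells (Homo sapiens) for antiproliferative activity, read by MTT assay (on this read-out lower numbers stand for stronger inhibition and higher numbers for weaker inhibition), compound 2 gives 28200 nM. Compound 1 gives "not active" (no number reported) in this assay, with no number behind it. Compound 3 likewise gives "not active" (no number reported) in this assay, again without a number. Going by the values given here, compound 2 thus holds the only figure in the set; the other two entries offer no value to set beside it, so no measured step is available.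

Compound 4 `CC(C)C[C@H]1O[C@H](COCc2ccccc2)[C@@H](OCc2ccccc2)[C@H](OCc2ccccc2)[C@H]1O` keeps the configuration of compound 2 and alters only the chain: methyl in place of hydrogen on a saturated chain carbon bound to two saturated chain carbons. Among the compounds with values here, no pair of measured compounds shows what such a change does. The expected step from compound 2 to compound 4 is a 1.1-fold lower number from compound 2 to compound 4 (0.05 log units; within the scatter), a size within the usual scatter and in no clear direction. For compound 4 the estimate in this assay is 25000 nM, expected to fall between 8000 nM and 80000 nM.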

Compound 4, half-maximal inhibitory concentration: 13900 nM
Beside the measured number, compound 4's estimate is 1.8-fold (0.25 log units) above it; the measured number falls inside the stated range.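

In this assay the change from propyl to isobutyl, methyl in place of hydrogen on a saturated chain carbon bound to two saturated chain carbons, brings a 2.0-fold lower number from compound 2 to compound 4 (0.31 log units; beyond the scatter) and gives the series its first measured step. With the configuration of compound 2 kept, this chain position therefore accepts the added methyl with activity retained and a modest shift towards stronger inhibition, although this rests on a single pair. The available observations concern only configuration among compound 1, compound 2 and compound 3, so none accounts for this chain step.

Going by these compounds, whether the same change would give a measurable number on the configurations of compound 1 or compound 3 remains open. Also open, on these data alone, is whether a longer chain or an amine in place of isobutyl would shift the number further, and in which direction.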